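The source may hold more compounds than are shown below. What is called first, only, known or untested is meant among the compounds shown, and "the series" means these compounds.

Within the data shown here, compound 1, `O=C1O[C@H]([C@@H](O)Cn2cc(-c3ccc(Br)cc3)nn2)C(OCc2ccccc2)=C1OCc1ccccc1`, is the only member of this set for which a number rather than a limit is known: in a functional assay on HCT-116 cells (Homo sapiens) for antiproliferative activity, read by MTT assay, with a stated time of 72 h (on this read-out lower numbers stand for stronger inhibition and higher numbers for weaker inhibition), compound 1 gives 9420 nM. Among the measured compounds shown here, compound 2, `COc1ccccc1-c1cn(C/C=C2\OC(=O)C(OCc3ccccc3)=C2OCc2ccccc2)nn1`, differs from compound 1 in more than one place, so no single step can be drawn between them. In this assay compound 2 reaches only the limit of the assay, > 100000 nM, which is a bound and not a number. This is recorded as the limit of > 100000 nM in this assay, at which 1 of the 2 values shown sits, and it leaves compound 1 as the sole anchor for the present comparison.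

Compound 3, `C[Si](C)(C)c1cn(C[C@H](O)[C@H]2OC(=O)C(OCc3ccccc3)=C2OCc2ccccc2)nn1`, is the unmeasured partner of compound 1. It differs from compound 1 by a group of 4 heavy atoms (3 carbon, 1 silicon; no ring) in place of a group of 7 heavy atoms (6 carbon, 1 bromine; one six-membered aromatic ring of carbon only), on an aromatic carbon. For the measured compounds named here, no measured pair in this set shows a step of this kind, so the direction cannot be read from the data. The group that leaves is larger than the one that enters, and compound 1 already sits in the weak range, so compound 3 is expected to stay near compound 1 or drift weaker, with an expected step of a 1.6-fold higher number from compound 1 to compound 3 (0.20 log units; within the scatter). Compound 3 is accordingly estimated at 15000 nM, within a range from 4000 nM to 60000 nM.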

Compound 3, half-maximal inhibitory concentration: 31800 nM
The estimate for compound 3 lay 2.1-fold (0.33 log units) below the measured number, and the stated range covers the measured number.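

In this assay, among these compounds, the exchange of the 4-bromophenyl on the aromatic carbon of the five-membered aromatic ring with 3 nitrogen for the group of 3 carbon and 1 silicon gives a 3.4-fold higher number from compound 1 to compound 3 (0.53 log units; beyond the scatter), a modest step but one beyond the usual scatter, so the first direct reading at this position shows that the group placed there does affect antiproliferative activity, and that this change weakens it. The position does not require an aromatic ring for a measurable effect, however: without any ring on this carbon, compound 3 still gives a number, 31800 nM, and not a limit of the assay. Nothing measured here accounts for the size or direction of this step.

Among the compounds shown here, the single step removes the ring and the bromine together, so the contribution of each remains unresolved. From the compounds shown here alone, how a phenyl without bromine, a tert-butyl group with carbon in place of the silicon, or an aminomethyl group would read at this position on the core of compound 1 remains open.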